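Removing the methoxybenzyl arm from an amide

This account rests on a few compounds, and the source may have more. Where it says the series, first, only, none or still open, it means among the compounds named here.

Compound 2 `COc1ccc(CNC(=O)c2cccn2-c2ccc3c(c2)B(O)OC3)cc1` carries the shared core with an amide whose nitrogen bears a 4-methoxybenzyl group. In an ADME assay on L929 cells (Mus musculus) for cytotoxicity, read by resazurin assay, with a stated time of 72 h (on this read-out higher numbers stand for weaker inhibition and lower numbers for stronger inhibition), compound 2 gives > 10 ug/mL, which is a limit of the assay and not a measured number. Its closest measured relative is compound 1 `O=C(NCc1ccccc1)c1cccn1-c1ccc2c(c1)B(O)OC2`, which lacks the methoxy group. In this assay compound 1 gives > 10 ug/mL, again a limit rather than a number. The change from one to the other, a step that the two limits leave unreadable from compound 1 to compound 2, therefore cannot be sized, since both readings stop at the limit of > 10 ug/mL in this assay, at which 2 of the 2 values shown sit.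

The compound still to be measured is compound 3 `CNC(=O)c1cccn1-c1ccc2c(c1)B(O)OC2`. It differs from compound 2 by hydrogen in place of 4-methoxyphenyl on a saturated chain carbon bound to an amide-type nitrogen, so the amide now carries only a methyl group on its nitrogen. No measured step touches this kind of change, and the one step shown is unreadable, so the only guide is that every value so far sits at the limit. For compound 3 the expected value in this assay is 20 ug/mL, with a range from 8 ug/mL to 60 ug/mL. The expected step that the limit leaves unreadable from compound 2 to compound 3 is accordingly none beyond the scatter.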

Compound 3, half-maximal inhibitory concentration: > 10 ug/mL
Compound 3 was reported as a limit; the forecaster's own chance of this, stated with the estimate: 85%; the middle value is on the limit's open side.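

Among the compounds shown here, compound 3 also stops at a limit rather than a number, so no step among compound 1, compound 2 and compound 3 can be read, because all three readings end at the same point: the limit of > 10 ug/mL in this assay, at which 3 of the 3 values shown sit. The compounds shown leave open whether the change from 4-methoxybenzyl to methyl alters cytotoxicity at all in this assay.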